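Swapping the Urea Aryl Group on a Shared Core

The compounds below may be only part of what the source reports. "The series", "measured", "known", "first", "only" and "open" are said of these compounds alone.

Measured in an assay on isolated protein for inhibition of proto-oncogene tyrosine-protein kinase receptor Ret variant V804M (Homo sapiens), read by 33P incorporation, with stated times of 15 min and 40 min; on this read-out lower numbers stand for stronger inhibition and higher numbers for weaker inhibition:
Compound 1, `O=C(Nc1ccc(Cl)cc1)Nc1ccc(Nc2ncnc3c2OCCN3)cc1`: 2280 nM
Compound 2, `O=C(Nc1ccc(Nc2ncnc3c2OCCN3)cc1)Nc1cc(Cl)cc(Cl)c1`: 1300 nM

Of the two numbers available, compound 2 carries the lower one, and its nearest neighbour is compound 1. Going by the values given here, the one measured step, a 1.8-fold lower number from compound 1 to compound 2 (0.24 log units; within the scatter), exchanges one chlorinated phenyl group for another on the urea nitrogen and stays within the scatter, so the two compounds cannot be told apart on this evidence.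

Compound 3, `O=C(Nc1ccc(Nc2ncnc3c2OCCN3)cc1)Nc1cccc2ccccc12`, keeps the shared core and the urea link but changes the aryl group once more: naphthalen-1-yl in place of 3,5-dichlorophenyl on an amide-type nitrogen. Among the compounds with values here, no measured step covers an exchange of a phenyl group for a fused two-ring aromatic group, so the only guide is that the single step seen so far, between two phenyl variants, did not move the number beyond the scatter. On that basis no step beyond the scatter is expected in this assay; the estimated step is a 1.2-fold higher number from compound 2 to compound 3 (0.06 log units; within the scatter). Compound 3 is therefore expected to give about 1500 nM in this assay, with a range from 500 nM to 4500 nM.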

Compound 3, half-maximal inhibitory concentration: > 10000 nM
Compound 3: no number, only a limit; the forecaster's own chance of this, stated with the estimate: 10%; at least 6.6-fold (0.82 log units) between middle value and limit.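

Among the two chlorinated phenyl groups, the aryl group on the urea nitrogen made no difference beyond the scatter, but naphthalen-1-yl shows that this position is not indifferent to the group it carries: in this assay the exchange gives an at least 7.6-fold higher number from compound 2 to compound 3 (0.88 log units; beyond the scatter), and the comparison with the other chlorinated compound gives an at least 4.3-fold higher number from compound 1 to compound 3 (0.64 log units; beyond the scatter). Two things change together in this exchange, as one six-membered aromatic ring bearing chlorine leaves and two six-membered aromatic rings of carbon only, with no chlorine, enter. The reading for compound 3 is a limit and not a number, so these steps give only the smallest possible size of the loss: the limit of > 10000 nM in this assay, at which 1 of the 3 values shown sits.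

The compounds shown cannot separate the effect of the second ring from the effect of losing the chlorine, and a plain unsubstituted phenyl group or a chlorinated naphthalen-1-yl group would be needed to pull the two apart. Also open, on these data alone, is whether naphthalen-2-yl, which has the same two rings joined to the urea nitrogen at a different point, would behave like compound 3.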